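A few compounds are considered here, and "the series" means these few. Any claim that something is new, unique, unknown or untested is made for them only; others in the source may bear on it.

Two compounds with the same core and the same amide have been measured in an ADME assay on the whole organism for pharmacokinetics, with Rattus norvegicus as the target; a higher number here means faster removal of the compound, a lower number slower removal. Compound 1 (`Cc1ccc(NC(=O)[C@H](COC(C)C)Oc2ncnc3c2cnn3-c2ccccc2Cl)nc1`), an isopropyl ether, gives 71 mL/min/kg, and compound 2 (`COC[C@H](Oc1ncnc2c1cnn2-c1ccccc1Cl)C(=O)Nc1ccc(C)cn1`), a methyl ether, gives 3.8 mL/min/kg. Compound 2 therefore holds the lower of the two numbers. Compound 3 (`COCC[C@H](Oc1ncnc2c1cnn2-c1ccccc1Cl)C(=O)Nc1ccc(C)cn1`) keeps the methyl ether of compound 2 but lengthens the chain, methoxymethyl to 2-methoxyethyl: methoxymethyl in place of methoxy on a saturated chain carbon, two bonds along the chain from a carbonyl carbon and an oxygen on an aromatic ring. The change sits on a saturated chain carbon, two bonds along the chain from a carbonyl carbon and an oxygen on an aromatic ring.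

Among the measured compounds shown here, only one measured step bears on this, and only indirectly: a 19-fold lower number from compound 1 to compound 2 (1.27 log units; beyond the scatter). That step replaced isopropyl with methyl on an oxygen, not the chain that changes here, so it shows that this pair responds strongly to a small ether change but cannot be carried over directly. With the terminal methyl kept, a move of that full size is not expected, though a modest rise is. The expected change is a 2.4-fold higher number from compound 2 to compound 3 (0.37 log units; beyond the scatter). For compound 3 the estimated clearance is 9 mL/min/kg, with an expected range from 3 mL/min/kg to 30 mL/min/kg.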

Compound 3, clearance in the Rattus norvegicus assay: 37 mL/min/kg
For compound 3 the middle estimate is 4.1-fold (0.61 log units) below the measured one; measured number above the stated range.
By their numbers in the Rattus norvegicus assay, from the lowest: compound 2; then compounds 3 and 1 (each within the scatter of the next).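

In the Rattus norvegicus assay compound 2 gives 3.8 mL/min/kg and compound 3 gives 37 mL/min/kg. In the Rattus norvegicus assay the change from methoxymethyl to 2-methoxyethyl gives a 9.7-fold higher number from compound 2 to compound 3 (0.99 log units; beyond the scatter) even though the ether stays a methyl ether, so this position responds to the length of the chain as well as to the group on the oxygen, which the first pair could not show. The isopropyl ether does not stand apart from the lengthened chain either, since the comparison gives a 1.9-fold lower number from compound 1 to compound 3 (0.28 log units; within the scatter) and leaves compound 2 as the only one of the three whose steps to both others lie beyond the scatter. In a physicochemical assay for lipophilicity (a higher number here means a more lipophilic compound, a lower number a more polar compound), compound 2 gives 3.4 and compound 3 gives 3.6. In the physicochemical assay the same change gives a number 0.20 log units higher from compound 2 to compound 3 (within the scatter) while the clearance step lies beyond the scatter, so the two read-outs do not move alike for this pair.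

Nothing available explains why the clearance moves so far at this position. Going by these compounds, it remains open whether a hydroxymethyl group, an ethyl ether, a longer chain or an amine at this saturated chain carbon would stay near compound 2 or near compound 3.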